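The source may hold more compounds than are shown below. What is called first, only, known or untested is meant among the compounds shown, and "the series" means these compounds.

Three compounds built on one shared core were measured in a physicochemical assay for solubility, read by HPLC, in phosphate buffer, measured as thermodynamic solubility, with a stated time of 48 h, at pH 7.2; a lower number here means a less soluble compound, a higher number a more soluble compound. Compound 1 `CCCOc1ccc(C[C@@H](Cc2ccccc2)C(=O)O)cc1CNC(=O)c1ccc(-c2cnccn2)cc1` gives 32.2 ug/mL. Compound 3 `CCCOc1ccc(C[C@@H](Cc2ccccc2)C(=O)O)cc1CNC(=O)c1ccc(-c2cccnc2)cc1` gives 69.5 ug/mL, a change of a 2.2-fold higher number from compound 1 to compound 3 (0.33 log units; beyond the scatter). Compound 2 `CCCOc1ccc(C[C@@H](Cc2ccccc2)C(=O)O)cc1CNC(=O)c1ccc(-c2ccccc2C)cc1` sits at a limit of this assay, < 1 ug/mL, so its position is known only as a bound and not as a number (the limit of < 1 ug/mL in this assay, at which 1 of the 3 values shown sits). The drop an at least 32-fold lower number from compound 1 to compound 2 (1.50 log units; beyond the scatter) and the rise an at least 69-fold higher number from compound 2 to compound 3 (1.84 log units; beyond the scatter) are both therefore open-ended on the side of compound 2.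

The step from compound 2 to compound 4 `CCCOc1ccc(C[C@@H](Cc2ccccc2)C(=O)O)cc1CNC(=O)c1ccc(-c2ccccc2)cc1` is hydrogen in place of methyl on an aromatic carbon. Within the data shown here, none of the measured steps touches the methyl alone; each exchanges the whole ring, so they show only that compound 2 lies far beneath compounds 1 and 3 and give no direct gauge of the methyl itself. The step is expected to be small, an at least 1.5-fold higher number from compound 2 to compound 4 (0.17 log units; that floor lies within the scatter), and it may stay within the scatter. Compound 4 is estimated at 1.5 ug/mL, in a range from 0.5 ug/mL to 5 ug/mL, with a real chance that this assay again reports only a limit.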

Compound 4, solubility: < 1 ug/mL
Compound 4 ended at the assay's limit; the forecaster's own chance of this, stated with the estimate: 40%; middle value at least 1.5-fold (0.17 log units) from the limit.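

Compound 4 stands at a limit of this assay, as compound 2 does, so taking away the methyl does not bring the compound to a readable number. The phenyl compound still lies far under the pyridin-3-yl and pyrazin-2-yl compounds, with an at least 69-fold lower number from compound 3 to compound 4 (1.84 log units; beyond the scatter) and an at least 32-fold lower number from compound 1 to compound 4 (1.50 log units; beyond the scatter), so the wide gap seen with compound 2 does not require the methyl. The step between compound 2 and compound 4 cannot be read, and the methyl itself remains ungauged: the limit of < 1 ug/mL in this assay, at which 2 of the 4 values shown sit.

As far as these compounds go, how far under the limit compound 2 and compound 4 lie remains open. Also open, from the compounds shown here alone, is whether an amine or a carboxylic acid on an aromatic carbon of the phenyl ring of compound 4 would give a readable number in this assay.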